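A few compounds are considered here, and "the series" means these few. Any claim that something is new, unique, unknown or untested is made for them only; others in the source may bear on it.

Measured so far in a functional assay on HT-29 cells (Homo sapiens) for antiproliferative activity, read by sulforhodamine B assay, with a stated time of 48 h; a higher number here means a weaker inhibitor, a lower number a stronger inhibitor:
- compound 1 `CCc1ccccc1NS(=O)(=O)c1ccc(N2CCNC2=O)cc1`: 240 nM
- compound 2 `O=C1NCCN1c1ccc(S(=O)(=O)Nc2ccc(I)cc2)cc1`: 650 nM
- compound 3 `O=C1NCCN1c1ccc(S(=O)(=O)Nc2ccc(F)c(F)c2)cc1`: 350 nM

Compound 2 sits at the upper end of these three values. The step to it from the other side is a 2.7-fold higher number from compound 1 to compound 2 (0.43 log units; beyond the scatter), whereas a 1.9-fold lower number from compound 2 to compound 3 (0.27 log units; within the scatter) leaves compound 2 and compound 3 hard to tell apart.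

Compound 4 `CCCCOc1ccc(NS(=O)(=O)c2ccc(N3CCNC3=O)cc2)cc1` has not yet been measured. It carries butoxy in place of iodo on an aromatic carbon, para to a large group: butoxy in place of iodo on an aromatic carbon.

For the measured compounds named here, no measured compound carries butoxy, so the evidence is indirect. The nearest guides are the swaps of the whole aromatic group on the sulfonamide nitrogen. These stayed small, with a 1.5-fold higher number from compound 1 to compound 3 (0.16 log units; within the scatter) and the two steps above. A modest step is therefore expected in this assay, leaning slightly lower, though no change beyond the scatter is also possible.

The expected step is a 1.6-fold lower number from compound 2 to compound 4 (0.21 log units; within the scatter).

For compound 4 the estimated value is 400 nM, with an expected range of 130 nM to 1200 nM.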

Compound 4, half-maximal inhibitory concentration: 630 nM
Compound 4: the middle estimate sits 1.6-fold (0.20 log units) below what was measured; the range from low to high includes it.
By their numbers in this assay, from the lowest: compounds 1, 3, 4 and 2 (each within the scatter of the next, the first and the last beyond it).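

In this assay, butoxy in place of iodo on the aromatic carbon para to a large group gives a 1.0-fold lower number from compound 2 to compound 4 (0.01 log units; within the scatter), so the two compounds cannot be told apart. This position therefore accepts butoxy, with 5 heavy atoms and a hydrogen-bond acceptor, as readily as iodo, with 1 heavy atom and no acceptor, and no loss of activity is seen in this comparison. Nothing available here accounts for why such different groups give matching values.

On these data alone, it remains open whether an amine or a carboxylic acid at this carbon would also leave the value in the same range. The shown compounds also do not tell whether methoxy or a chain longer than butoxy would match compound 4.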